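Phenoxy to Dimethylamino: an Expected Step from Compound 3

This account rests on a few compounds, and the source may have more. Where it says the series, first, only, none or still open, it means among the compounds named here.

Compound 1, `COc1cc(C)cc(-c2c(-c3ccnc(-c4ccc(C(C)=O)cc4)c3)cnn2CC#N)c1`, in a functional assay on K562 cells (Homo sapiens) for inhibition, read by sulforhodamine B assay, with a stated time of 48 h; a higher number here means a weaker inhibitor of growth, a lower number a stronger inhibitor of growth: 795 nM
Compound 2, `COc1cc(C)cc(-c2nn(CC#N)cc2-c2ccc(-c3cccc(C(C)=O)c3)nc2)c1`, in this assay: 365 nM
Compound 3, `Cc1cc(O)cc(-c2nn(CC#N)cc2-c2ccnc(-c3ccc(Oc4ccccc4)cc3)c2)c1`, in this assay: 4870 nM

Of the compounds shown here, three that share a common core have been measured in this assay. Compound 3 gives the highest number of the three. Its nearest neighbour is compound 1, which lies below it by a gap beyond the usual scatter; compound 2 lies lower still, the furthest of the three, again beyond the scatter. No two of the measured compounds differ in only one place, so no single structural change can be read off from the measured numbers alone.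

Compound 4, `Cc1cc(O)cc(-c2nn(CC#N)cc2-c2ccnc(-c3ccc(N(C)C)cc3)c2)c1`, differs from compound 3 in one place: dimethylamino in place of phenoxy on an aromatic carbon. For the measured compounds named here, no measured pair shows this change, so its size and direction are open. The measured compounds with smaller groups at the corresponding position of the outer ring do give lower numbers, though they also differ elsewhere, so this is only a loose hint.

Because compound 3 gives 4870 nM, the highest number of the three, a modest move downward is expected, though a value within the scatter cannot be ruled out. For compound 4 in this assay the estimate is 3000 nM, within 800 nM to 12000 nM. That expectation amounts to a 1.6-fold lower number from compound 3 to compound 4 (0.21 log units; within the scatter).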

Compound 4, concentration for 50% growth inhibition: 2550 nM
Compound 4: the middle estimate sits 1.2-fold (0.07 log units) above what was measured; low and high end bracket the measured number.
By their numbers in this assay, from the lowest: compound 2; then compound 1; then compounds 4 and 3 (each within the scatter of the next).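

In this assay, for the compounds shown here, putting dimethylamino in place of phenoxy on an aromatic carbon, para to a large group, gives a 1.9-fold lower number from compound 3 to compound 4 (0.28 log units; within the scatter), the first change at this position that can be read on its own. The step takes away the six-membered aromatic ring of carbon only and cuts the group from 7 heavy atoms to 3, while the hydrogen-bond donor and acceptor counts and the net charge stay as they were, and the number still does not move beyond the scatter. For this one pair, then, a much smaller group at this place is not enough on its own to produce a clear shift, and nothing shown gives a measured reason for that outcome.

The compounds shown leave open whether a different kind of group at this place, such as a morpholine ring, a primary amine or a carboxylic acid, would move the number beyond the scatter. They also leave open whether the exchange of phenoxy for dimethylamino would give a similar step on another core, such as that of compound 1.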